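A few compounds are considered here, and "the series" means these few. Any claim that something is new, unique, unknown or untested is made for them only; others in the source may bear on it.

Three compounds have so far been measured in a functional assay (Homo sapiens) for inhibition of Nucleic Acid, tested at 100 uM; a higher number here means more inhibition at the concentration tested (going by the name of the read-out), a lower number less inhibition:

Compound 1 `[N-]=[N+]=Nc1nccc2ncn([C@H]3C[C@H](O)[C@@H](CO)O3)c12` gives 14%.
Compound 2 `OC[C@H]1OC(n2cnc3c(Nc4ccccc4)nccc32)[C@H](O)[C@@H]1O` gives 4%.
Compound 3 `OC[C@H]1O[C@@H](n2cnc3c(SCc4ccccc4)nccc32)C[C@@H]1O` gives 18%.

All three numbers are small, so none of the compounds blocks much at the tested concentration. Compound 2 carries the lowest of the three numbers. Its nearest neighbour in this assay is compound 1, whose number sits within the scatter of repeated measurements, so the two cannot be told apart. Compound 3 lies furthest away, with a number beyond the scatter, so compound 3 does show more inhibition than compound 2.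

Compound 4 `CNc1nccc2c1ncn2C1O[C@H](CO)[C@@H](O)[C@H]1O` has not yet been measured. It shares its core with compound 2 and differs in a single place: methyl in place of phenyl on a nitrogen on an aromatic ring. Put another way, the anilino group of compound 2 becomes a methylamino group in compound 4.

Going by the values given here, no pair of measured compounds differs by a change of this kind, so there is no measured step to lean on. Given that compound 2 already sits near the bottom of the range, the step of a number 4 percentage points higher from compound 2 to compound 4 (within the scatter) is expected to be small, in either direction, and not beyond the scatter. Compound 4 is therefore estimated to give 8%, with a likely range from 0% to 20%.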

Compound 4, a percentage reported as inhibition, at one concentration (the size of the read-out at that concentration, not a potency): 8%
For compound 4 middle estimate and measured number coincide at the digits printed, within the range that was stated.
By their numbers in this assay, from the lowest: compounds 2, 4, 1 and 3 (each within the scatter of the next, the first and the last beyond it).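

Going by these compounds alone, the pair of compound 2 and compound 4 gives the first direct comparison in this assay of two compounds that differ in one place, here on a nitrogen on an aromatic ring. Replacing phenyl, with its six-membered aromatic ring of carbon only, by a single-carbon methyl gives a step of a number 4 percentage points higher from compound 2 to compound 4 (within the scatter) and so the anilino and methylamino compounds cannot be told apart at the tested concentration, even though the swap removes the whole ring. No separate measurement is available that could explain this result.

On these data alone, what other groups would read at this position stays open, for example an unsubstituted amine, a longer chain such as butyl on the same nitrogen, or a group carrying a carboxylic acid. As far as these compounds go, the comparison also rests on a single pair, so it remains unknown whether the same swap from phenyl to methyl would read the same way on a molecule that differs elsewhere, such as one built like compound 1 or compound 3.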